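Swapping a Chloromethyl Carbonyl for a Chlorothiazole Carbonyl

This account rests on a few compounds, and the source may have more. Where it says the series, first, only, none or still open, it means among the compounds named here.

compound 1 `C=C(C)C(=O)Nc1cccc(-c2nc3ccccc3s2)c1`: > 25000 nM
compound 2 `O=C(CCl)Nc1cccc(-c2nc3ccccc3s2)c1`: 8500 nM

In an ADME assay on BJ cells (Homo sapiens) for inhibition, with a stated time of 72 h (on this read-out higher numbers stand for an effect only at larger amounts of compound and lower numbers for an effect already at smaller amounts), compound 1 reaches only a limit, > 25000 nM. Going by the values given here, compound 2 gives 8500 nM in this assay, the only number among the two results. The other result, that of compound 1, is a limit (the limit of > 25000 nM in this assay, at which 1 of the 2 values shown sits). Among the compounds with values here, the one measured step, an at least 2.9-fold lower number from compound 1 to compound 2 (0.46 log units; beyond the scatter), introduced the chloromethyl group. Compound 3 `O=C(Nc1cccc(-c2nc3ccccc3s2)c1)c1cnc(Cl)s1` differs from compound 2 by 2-chloro-1,3-thiazol-5-yl in place of chloromethyl on a carbonyl carbon. Since that step removes the very group the measured step brought in, a move back toward the limit is expected. Compound 3 is estimated at 20000 nM, within 5000 nM to 60000 nM. For compound 3 this means an expected step of a 2.4-fold higher number from compound 2 to compound 3 (0.37 log units; beyond the scatter).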

Compound 3, half-maximal effective concentration: > 25000 nM
Compound 3 was reported as a limit; the forecaster's own chance of this, stated with the estimate: 50%; middle value at least 1.2-fold (0.09 log units) away from the limit.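

In this assay, placing 2-chloro-1,3-thiazol-5-yl on the carbonyl carbon in place of chloromethyl gives an at least 2.9-fold higher number from compound 2 to compound 3 (0.46 log units; beyond the scatter), so a chlorine in the new group is not enough to retain the readable effect seen with compound 2. Compound 3 reaches only a limit, as does compound 1: the limit of > 25000 nM in this assay, at which 2 of the 3 values shown sit. The step between these two limits cannot be read.

Compound 2 therefore remains the only one of the three with a number. As far as these compounds go, whether bromomethyl or a longer chain ending in chlorine on the same carbonyl carbon would also give a number remains open.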